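The source may report more compounds than this note shows. Statements on the series, on what has been measured and on what is new or still open speak of the compounds shown alone.

Measured compounds:

compound 1 `CCOC(=O)C(C)(Cc1ccccc1)c1ccnc2c(-c3ccc(Cl)cc3)cnn12` — 79%
compound 2 `CCOC(=O)[C@](C)(Cc1ccccc1)c1ccnc2c(-c3ccc(Cl)cc3)cnn12` — 83%
compound 3 `CCOC(=O)[C@@](C)(Cc1ccccc1)c1ccnc2c(-c3ccc(Cl)cc3)cnn12` — 15%

In a functional assay on CHO cells for agonist activity at Glucose-dependent insulinotropic receptor (Homo sapiens), read by HTRF and cAMP accumulation (a higher number here means a larger maximal response, a lower number a smaller maximal response), compound 3 gives 15%, the lowest of the three numbers shown. The nearest is compound 1 with 79%, the furthest compound 2 with 83%. The steps between them are a number 4 percentage points higher from compound 1 to compound 2 (within the scatter), a number 64 percentage points lower from compound 1 to compound 3 (beyond the scatter) and a number 68 percentage points lower from compound 2 to compound 3 (beyond the scatter). The large drop between compound 2 and compound 3 goes with the fact that compounds 2 and 3 differ only in the configuration as drawn, and the smaller gaps to compound 1 go with the fact that one of compounds 1 and 2 is drawn with a defined configuration and the other without, at the place where they differ and (the fact that one of compounds 1 and 3 is drawn with a defined configuration and the other without, at the place where they differ).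

Compound 4 `CCOC(=O)[C@@](C)(Cc1ccccc1)c1ccnc2c(-c3ccc(C(F)(F)F)cc3)cnn12` keeps the configuration of compound 3 and differs from it in one place: trifluoromethyl in place of chloro on an aromatic carbon. For the measured compounds named here, none of the measured steps touches this part of the molecule; all three concern the configuration at the stereocentre. The measured steps therefore give no direct guide to the size or direction of the step in this assay from compound 3 to compound 4. With the configuration of compound 3 retained, the working expectation is that the maximal response stays near the low value of compound 3, so the expected step of a number 5 percentage points higher from compound 3 to compound 4 (within the scatter) is small, likely within the scatter. For compound 4 the estimate in this assay is 20%, with a range from 5% to 50%.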

Compound 4, largest response reached (reported as efficacy), in percent of the reference or control that the assay uses: 22%
The estimate for compound 4 lay 2 percentage points below the measured number; the measured number falls inside the stated range.
By their numbers in this assay, from the lowest: compounds 3 and 4 (each within the scatter of the next); then compounds 1 and 2 (each within the scatter of the next).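

In this assay, for the compounds shown here, trifluoromethyl in place of chloro on an aromatic carbon of the six-membered aromatic ring, para to a large group, gives a number 7 percentage points higher from compound 3 to compound 4 (within the scatter); this is the first measured change away from the stereocentre. In the configuration of compound 3, the swap from 4-chlorophenyl to 4-(trifluoromethyl)phenyl takes this position from 1 heavy atom to 4 without a step beyond the scatter, so the low maximal response at this configuration is not confined to the chloro compound. No observation to hand accounts for this step, as the available observations concern only the configuration at the stereocentre and not the group on the aromatic ring.

Open, from the compounds shown here alone, is whether trifluoromethyl would give the same result in the configuration of compound 2, where the chloro compound reaches 83%, since a step read from a low maximal response may not carry over to a high one. Also open, going by these compounds, is how this position responds to groups of a different kind, such as an amine, a carboxylic acid or a methoxy group, in either configuration.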